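This account rests on a few compounds, and the source may have more. Where it says the series, first, only, none or still open, it means among the compounds named here.

Compound 1 `O=c1ccn([C@@H]2C=C[C@H](CO)C2)c(=O)[nH]1`: > 100000 nM
Compound 2 `Nc1ncnc2c1ncn2[C@@H]1C=C[C@H](CO)C1`: > 100000 nM

Both entries come from a functional assay on cells (Homo sapiens) for cytotoxicity; on this read-out lower numbers stand for stronger inhibition and higher numbers for weaker inhibition. Compound 2 stands at > 100000 nM, which is a limit and not a number. Compound 1 also gives a limit, > 100000 nM. The whole measured set therefore sits at one ceiling: the limit of > 100000 nM in this assay, at which 2 of the 2 values shown sit.

The next case is compound 3 `OC[C@H]1C=C[C@@H](n2cnc3c(O)ncnc32)C1`, with hydroxy in place of amino on an aromatic carbon. Going by the values given here, no measured pair shows what this change does in this assay, and two limits give no step size to carry over. The expectation is no step beyond the scatter, and the measured basis is only compound 2 at > 100000 nM. The estimated step is a step that the limit leaves unreadable from compound 2 to compound 3. A further limit is the most likely report. Compound 3 is expected at 120000 nM, with an estimated range of 50000 nM to 300000 nM.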

Compound 3, half-maximal inhibitory concentration: > 100000 nM
Compound 3 was reported as a limit; the forecaster's own chance of this, stated with the estimate: 90%; the middle value lies beyond the limit too.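

Compound 2 and compound 3 are both reported as limits in this assay, so no step can be read for hydroxy in place of amino on an aromatic carbon: the limit of > 100000 nM in this assay, at which 3 of the 3 values shown sit.

The compounds shown leave open what size of effect, if any, this change has on a measurable value in this assay.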